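Bromo to fluoro exchange on an aromatic carbon, three compounds

The source may hold more compounds than are shown below. What is called first, only, known or untested is meant among the compounds shown, and "the series" means these compounds.

compound 1 `COc1cc2ncnc(Nc3cc(C(F)(F)F)ccc3F)c2c(OC)c1OC` gives 29.2% in a functional assay on PC-3 cells (Homo sapiens) for inhibition, read by MTT assay, with a stated time of 72 h, tested at 10 uM; on this read-out lower numbers stand for less inhibition of growth and higher numbers for more inhibition of growth at the one concentration tested
compound 2 `COc1cc2ncnc(Nc3cc(C(F)(F)F)ccc3Br)c2c(OC)c1OC` gives 25.3% in this assay
compound 3 `COc1cc2ncnc(Nc3ccc(Br)cc3)c2c(OC)c1OC` gives 22.2% in this assay

One structural change has already been measured within the set, from compound 2 to compound 1: fluoro in place of bromo on an aromatic carbon. The step it made was a number 3.9 percentage points higher from compound 2 to compound 1 (within the scatter). All three measured compounds give numbers that lie within the usual scatter of one another, so no ordering among them is read from these data.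

Compound 3 and compound 2 share the same core, but the difference between the two cores is not broken down here.

Compound 4 `COc1cc2ncnc(Nc3ccc(F)cc3)c2c(OC)c1OC` has not yet been measured. It differs from compound 3 by fluoro in place of bromo on an aromatic carbon. The surroundings are not the same as in the measured pair: in compound 4 the exchanged atom sits para to a large group, whereas in compound 1 it sits ortho to a large group and para to a trifluoromethyl group. The change is therefore the same kind of change, not the same one.

In this assay the step from compound 3 to compound 4 is expected to be a number 2.8 percentage points higher from compound 3 to compound 4 (within the scatter), beside the earlier one, resting on the within-scatter size of a number 3.9 percentage points higher from compound 2 to compound 1 (within the scatter) in the measured pair. Compound 4 is accordingly estimated at 25%, with the likely range from 14% to 36%.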

Compound 4, percent growth inhibition at one concentration: 9.1%
Estimate against measurement, compound 4: 15.9 percentage points above; measured number outside the range, below it.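

On the core of compound 3, with the exchanged atom para to a large group, fluoro in place of bromo gives a number 13.1 percentage points lower from compound 3 to compound 4 (beyond the scatter) in this assay. The exchange therefore has no fixed size that carries from one core to the other in this series, and a step read on the core of compound 2 cannot be used as an estimate on the core of compound 3: the same change on two cores in this assay, a number 3.9 percentage points higher (within the scatter) from compound 2 to compound 1 and a number 13.1 percentage points lower (beyond the scatter) from compound 3 to compound 4, 17 percentage points apart, beyond the scatter of two such steps

What this does not show is which feature of the two cores accounts for the gap, as the two pairs differ both in the trifluoromethyl group and in the surroundings of the exchanged atom, and no compound shown separates the two; with only one pair on each core, it also gives no general rule for either core.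

Still open, as far as these compounds go, is how chloro, methyl, a nitrile or an amine would read in place of the halogen on either core in this assay. Also open, from the compounds shown here alone, is whether a trifluoromethyl group alone, added to compound 3 and compound 4 with the halogen left where it is, would bring the bromo and fluoro compounds back within the scatter of each other.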